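The source may hold more compounds than are shown below. What is called first, only, known or untested is meant among the compounds shown, and "the series" means these compounds.

Compound 1 `Cc1c(Cc2c(F)cccc2F)nc(N(C)C(C)C)[nH]c1=O`: 79000 nM
Compound 2 `Cc1c(Cc2c(F)cccc2F)nc(N(C)c2ccccc2)[nH]c1=O`: > 73000 nM

These values come from an ADME assay on MT4 cells (Homo sapiens) for cytotoxicity, read by MTT assay, with a stated time of 4 days; on this read-out lower numbers stand for higher toxicity in this test and higher numbers for lower toxicity in this test. For compound 2, the reading of > 73000 nM is a limit of the assay and not a number. For the measured compounds named here, the one measured step is a step that the limit leaves unreadable from compound 1 to compound 2, so it offers no size to carry forward. Compound 3 `CCCN(CCC)c1nc(Cc2c(F)cccc2F)c(C)c(=O)[nH]1` has not been measured, and its change from compound 2 is dipropylamino in place of methyl(phenyl)amino on an aromatic carbon. Compound 1, which has isopropyl on that nitrogen instead of phenyl, gives 79000 nM, and this value anchors the expectation. The expected result is an at least 1.2-fold lower number from compound 2 to compound 3 (0.08 log units; that floor lies within the scatter), with no shift beyond the scatter in this assay. Compound 3 is estimated at 60000 nM, with an expected range of 20000 nM to 150000 nM.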

Compound 3, half-maximal cytotoxic concentration: > 74000 nM
Compound 3 ended at the assay's limit (the forecaster's own chance of this, stated with the estimate: 35%); middle value at least 1.2-fold (0.09 log units) away from the limit.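

For the compounds shown here, compound 3 reads > 74000 nM, a limit and not a number, and no step to it from compound 1 or compound 2 can be read. Still open, as far as these compounds go, is how compound 2 and compound 3 truly compare with each other and with compound 1.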